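From Cyclopropylamino to Methylsulfanyl at the Assay Limit

A few compounds are considered here, and "the series" means these few. Any claim that something is new, unique, unknown or untested is made for them only; others in the source may bear on it.

In an ADME assay on MOLT-3 cells (Homo sapiens) for cytotoxicity, with a stated time of 7 days (a lower number here means that less compound is tolerated, a higher number that more compound is tolerated), compound 3 `Nc1nc(NC2CC2)c2ncn(/C=C3/CC3(CO)CO)c2n1` stands at > 20000 nM as a limit of the assay, not a number. Compound 1 `Nc1nc(OCc2ccccc2)c2ncn(/C=C3/CC3(CO)CO)c2n1` likewise shows > 20000 nM as a limit. Compound 2 `CC(C)Nc1nc(N)nc2c1ncn2/C=C1/CC1(CO)CO` has "not determined" (no result reported) as its entry. Compound 4 `CSc1nc(N)nc2c1ncn2/C=C1/CC1(CO)CO` carries methylsulfanyl in place of cyclopropylamino on an aromatic carbon, with methylsulfanyl in place of cyclopropylamino on an aromatic carbon as the counted difference. Going by the values given here, the one measured step that bears on this is a step that the two limits leave unreadable from compound 1 to compound 3 and it also exchanges a group on an aromatic carbon, yet it offers no size to carry over. The only anchor is the limit of > 20000 nM in this assay, at which 2 of the 3 values shown sit, and it sets no direction. In this assay no step beyond the scatter is therefore expected. The expected change by this estimate is a number no higher from compound 3 to compound 4 (the limit leaves the size open) and no more. Compound 4 is estimated at 20000 nM with an expected range from 8000 nM to 40000 nM as its bounds.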

Compound 4, half-maximal cytotoxic concentration: > 20000 nM
Compound 4 was reported as a limit; the forecaster's own chance of this, stated with the estimate: 65%; the middle value lies on the limit itself.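

Going by these compounds alone, neither the step from compound 3 to compound 4 nor the one from compound 1 to compound 4 can be read, as each joins two assay limits. The compounds shown leave open whether methylsulfanyl, cyclopropylamino and benzyloxy differ in tolerated concentration at all.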